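Compound 3 to compound 4: exchange of the aryl group

The compounds below may be only part of what the source reports. "The series", "measured", "known", "first", "only" and "open" are said of these compounds alone.

Values in a functional assay on MCF7 cells (Homo sapiens) for inhibition, with a stated time of 96 h (a higher number here means a weaker inhibitor, a lower number a stronger inhibitor), for the compounds measured so far:
- compound 1 `COc1cc(C(=O)c2cn(-c3cccc(C)c3)cc2-c2ccsc2)cc(OC)c1OC` gives 65 nM
- compound 2 `COc1cc(C(=O)c2cn(-c3cccc(C)c3)cc2-c2ccoc2)cc(OC)c1OC` gives 21 nM
- compound 3 `COc1cc(C(=O)c2cn(-c3cccc(C)c3)cc2-c2ncco2)cc(OC)c1OC` gives 75 nM

Compound 3 shares the upper end of this small set with compound 1. The two steps that reach it are (a 1.2-fold higher number from compound 1 to compound 3 (0.06 log units; within the scatter)) and (a 3.6-fold higher number from compound 2 to compound 3 (0.55 log units; beyond the scatter)). Compound 4 `COc1cc(C(=O)c2cn(-c3ccc(F)cc3)cc2-c2ncco2)cc(OC)c1OC` carries 4-fluorophenyl in place of 3-methylphenyl on an aromatic nitrogen.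

Among the compounds with values here, no measured step makes this exchange, since all three alter a different group. They bear on it only as a guide to the size of change in the series, together with (a 3.1-fold lower number from compound 1 to compound 2 (0.49 log units; beyond the scatter)). They run from within the scatter to modest. With no direct evidence for either direction, no clear shift is expected in this assay, and the range is kept wide. The expected change is (a 1.2-fold higher number from compound 3 to compound 4 (0.08 log units; within the scatter)). The estimated value for compound 4 is 90 nM (expected range 25 nM to 300 nM).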

Compound 4, half-maximal inhibitory concentration: 93 nM
Beside the measured number, compound 4's estimate is 1.0-fold (0.01 log units) below it; the measured number falls inside the stated range.
By their numbers in this assay, from the lowest: compound 2; then compounds 1, 3 and 4 (each within the scatter of the next).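

In this assay, within the data shown here, the first exchange at the aromatic nitrogen gives a 1.2-fold higher number from compound 3 to compound 4 (0.09 log units; within the scatter), so with 1,3-oxazol-2-yl on the core this position accepts 4-fluorophenyl in place of 3-methylphenyl without a shift beyond the scatter. The two groups have the same heavy-atom count and neither has a hydrogen-bond donor or acceptor, but the step changes both the substituent and its place on the phenyl ring, so the pair cannot separate these two changes. No measurement of any property accompanies this result, and the step therefore comes with no explanation.

Still open, on these data alone, is whether the exchange at the aromatic nitrogen stays within the scatter when furan-3-yl, the group of compound 2, replaces 1,3-oxazol-2-yl. Also open, as far as these compounds go, is how this position responds to a phenyl ring bearing an amine or a carboxylic acid.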